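The source may hold more compounds than are shown below. What is called first, only, known or untested is meant among the compounds shown, and "the series" means these compounds.

Compound 1, `N#Cc1cc(O)cc(OC(=O)N2CCC(C(c3ccccc3)c3ccccc3)CC2)c1`: 98.2 nM
Compound 2, `N#Cc1cccc(OC(=O)N2CCC(C(c3ccccc3)c3ccccc3)CC2)c1`: 36.5 nM
Compound 3, `COc1cc(C#N)cc(OC(=O)N2CCC(C(c3ccccc3)c3ccccc3)CC2)c1`: 98 nM

In an assay on isolated protein for inhibition of Monoglyceride lipase (Rattus norvegicus), read by fluorescence, with stated times of 15 min and 3 h (on this read-out higher numbers stand for weaker inhibition and lower numbers for stronger inhibition), compound 3 stands second highest of the three numbers; its value and that of compound 1 lie within the scatter of each other, while a 2.7-fold higher number from compound 2 to compound 3 (0.43 log units; beyond the scatter) is a modest step beyond it. Compound 4, `N#Cc1cccc(OC(=O)N2CCC(C(c3ccccc3)c3ccccc3)CC2)n1`, carries 6-cyanopyridin-2-yl in place of 3-cyano-5-methoxyphenyl on an oxygen next to a carbonyl group. Because a 2.7-fold higher number from compound 2 to compound 3 (0.43 log units; beyond the scatter) turned on the methoxy group that now leaves, that step bears on the change directly, and a 2.7-fold lower number from compound 1 to compound 2 (0.43 log units; beyond the scatter) shows a shift of similar size when a hydroxy group leaves. Within the data shown here, no measured step covers the ring nitrogen. A modest downward step is therefore expected, a 2.5-fold lower number from compound 3 to compound 4 (0.39 log units; beyond the scatter). Compound 4 is estimated at 40 nM, with a range from 12 nM to 130 nM.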

Compound 4, half-maximal inhibitory concentration: 75.8 nM
The estimate for compound 4 lay 1.9-fold (0.28 log units) below the measured number; the measured number falls inside the stated range.
By their numbers in this assay, from the lowest: compound 2; then compounds 4, 3 and 1 (each within the scatter of the next).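

With 6-cyanopyridin-2-yl on an oxygen next to a carbonyl group, this assay gives a 1.3-fold lower number from compound 3 to compound 4 (0.11 log units; within the scatter) and a 1.3-fold lower number from compound 1 to compound 4 (0.11 log units; within the scatter), so this group does not separate compound 4 from either substituted phenyl compound. Among these compounds, the comparison with the unsubstituted 3-cyanophenyl group gives the first reading of a ring nitrogen, a 2.1-fold higher number from compound 2 to compound 4 (0.32 log units; beyond the scatter), and compound 2 keeps the lowest number of the four. Nothing available explains this result. The compounds shown leave open how an amine or a carboxylic acid on this ring would read.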